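The source may report more compounds than this note shows. Statements on the series, on what has been measured and on what is new or still open speak of the compounds shown alone.

Measured compounds in a functional assay on SK-MEL-2 cells (Homo sapiens) for cytotoxicity, read by sulforhodamine B assay, with a stated time of 48 h; a lower number here means a stronger inhibitor of growth, a higher number a weaker inhibitor of growth:
compound 1 `ClCc1cccc(Cn2cnc3ncnc(Cl)c32)c1`, compound 1 gives 5750 nM
compound 2 `ClCc1cccc(Cn2cnc3c(Cl)ncnc32)c1`, compound 2 gives 21900 nM
compound 3 `ClCc1cccc(Cn2cnc3c(Cl)nc(Cl)nc32)c1`, compound 3 gives 1990 nM

Compound 1 and compound 2 are built from the same atoms joined differently; the difference between the two cores is not broken down here. Compound 3 differs from compound 2 by one change, (chloro in place of hydrogen on an aromatic carbon), and this change gave an 11-fold lower number from compound 2 to compound 3 (1.04 log units; beyond the scatter). Compound 4 `ClCc1cccc(Cn2cnc3nc(Cl)nc(Cl)c32)c1` is not yet measured; it differs from compound 1 by chloro in place of hydrogen on an aromatic carbon, the same change at the same kind of place. Because the change gave an 11-fold lower number from compound 2 to compound 3 (1.04 log units; beyond the scatter), a step of like direction is expected for compound 4, though its size is estimated somewhat smaller, a 7.2-fold lower number from compound 1 to compound 4 (0.86 log units; beyond the scatter). Compound 4 is therefore expected to give 800 nM in this assay, estimated between 250 nM and 2500 nM.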

Compound 4, concentration for 50% growth inhibition: 1770 nM
Estimate against measurement, compound 4: 2.2-fold (0.34 log units) below, and the stated range covers the measured number.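

In this assay the change of hydrogen to chloro on an aromatic carbon, between two ring nitrogen atoms, gave a 3.2-fold lower number from compound 1 to compound 4 (0.51 log units; beyond the scatter) on the core of compound 1. The direction matched the earlier step, but the size did not carry over unchanged: the same change on two cores in this assay, an 11-fold lower number (1.04 log units; beyond the scatter) from compound 2 to compound 3 and a 3.2-fold lower number (0.51 log units; beyond the scatter) from compound 1 to compound 4, 3.4-fold (0.53 log units) apart, beyond the scatter of two such steps.
These two pairs show that the direction held on both cores, but they do not explain the gap in size or show that the step would hold on any further core.

As far as these compounds go, only hydrogen and chloro appear at this carbon, so the effect of an amine or a methoxy group there remains open. From the compounds shown here alone, the effect of replacing the chloromethyl group with a longer chain also remains open.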